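Phenyl for butyl on a carbamate nitrogen

The source may hold more compounds than are shown below. What is called first, only, known or untested is meant among the compounds shown, and "the series" means these compounds.

Compound 1, `CCCCNC(=O)OC/C=C(\C)C1=CC(=O)C(C)(C)O1`, gives 7.7 ug/mL in a functional assay on FM3A cells (Mus musculus) for inhibition; on this read-out lower numbers stand for stronger inhibition and higher numbers for weaker inhibition.
Compound 2, `C/C(=C\C=C/C1CCCCC1)C1=CC(=O)C(C)(C)O1`, gives 10.8 ug/mL in this assay.
Compound 3, `COc1ccc(/C=C/C=C(\C)C2=CC(=O)C(C)(C)O2)cc1`, gives 25 ug/mL in this assay.

Three compounds share one core and differ in the side chain attached to it. Compound 1 has the lowest of the three numbers in this assay. Its gap to compound 2 lies within the usual scatter, so the two cannot be told apart; its gap to compound 3 lies beyond the scatter, so compound 1 inhibits more strongly than compound 3.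

Compound 4, `C/C(=C\COC(=O)Nc1ccccc1)C1=CC(=O)C(C)(C)O1`, is not yet measured. It differs from compound 1 in one place: phenyl in place of butyl on an amide-type nitrogen. Going by the values given here, no measured pair shows what this change does in this assay, so nothing in the data points to a clear direction. The expected step is small, a 1.0-fold higher number from compound 1 to compound 4 (0.02 log units; within the scatter), with no change beyond the scatter expected. For compound 4 the estimate in this assay is 8 ug/mL, expected to fall between 3 ug/mL and 20 ug/mL.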

Compound 4, half-maximal inhibitory concentration: > 200 ug/mL
Compound 4 gave a limit, no number; the forecaster's own chance of this, stated with the estimate: 5%; middle value at least 25-fold (1.39 log units) from the limit.
By their numbers in this assay, from the lowest: compounds 1 and 2 (each within the scatter of the next); then compound 3. At a limit, above all of these: compound 4.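

At this position the group is far from interchangeable: in this assay, phenyl in place of butyl on the amide-type nitrogen gives an at least 25-fold higher number from compound 1 to compound 4 (1.41 log units; beyond the scatter). Going by these compounds alone, compound 4 stands at a limit of the assay, not at a number: the limit of > 200 ug/mL in this assay, at which 1 of the 4 values shown sits. Compound 1, compound 2 and compound 3 differ from one another in more than one place, so they gave no direct reading of any single change, and this pair is the first to show that inhibition depends strongly on what sits on this nitrogen.

From the compounds shown here alone, one swap cannot separate the effect of having a ring there from that of losing the open chain, so it remains unknown which of the two matters. Going by these compounds, whether cyclohexyl, benzyl or a shorter chain such as propyl on this nitrogen would keep the inhibition seen with compound 1 also stays open.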